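Methyl for trifluoromethyl on the aryl piperazine

A few compounds are considered here, and "the series" means these few. Any claim that something is new, unique, unknown or untested is made for them only; others in the source may bear on it.

Measured compounds:
compound 1 `CC1(c2ccccc2)CC(=O)N(CC(=O)N2CCN(c3cccc(C(F)(F)F)c3)CC2)C1=O` — "not active" (no number reported)
compound 2 `CC1(c2ccccc2)CC(=O)N(CC(=O)N2CCN(c3ccccc3)CC2)C1=O` — 100 mg/kg
compound 3 `CC1(c2ccccc2)CC(=O)N(CC(=O)N2CCN(c3ccc(F)cc3)CC2)C1=O` — "not active" (no number reported)

Three compounds share one core and differ only in the group on the aromatic ring at the far end. In a functional assay on the whole organism (strain CD-1) with Mus musculus as the target, with a stated time of 0.5 h (a lower number here means that less compound is needed, a higher number that more compound is needed for the effect), compound 2, carrying an unsubstituted ring, gives 100 mg/kg. Compound 1 was recorded as "not active" (no number reported), so it stands without a number, and compound 3 likewise gave "not active" (no number reported). Of the three, only compound 2 delivers a measurable dose.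

Compound 4 `Cc1cccc(N2CCN(C(=O)CN3C(=O)CC(C)(c4ccccc4)C3=O)CC2)c1` is not yet measured. It differs from compound 1 by methyl in place of trifluoromethyl on an aromatic carbon. Among the measured compounds shown here, no step between two measured compounds matches this change, so its size cannot be read from the data. For the measured compounds named here, since compound 1 has no number and the one active compound, compound 2, needs a high dose, the expectation for compound 4 in this assay is a weak effect at best, with a real chance that again no number is obtained. Compound 4 is estimated at 100 mg/kg, within 30 mg/kg to 300 mg/kg.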

Compound 4, minimum effective dose: "not active" (no number reported)
The entry for compound 4 holds no number; no gap can be computed for the estimate.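

Compound 1 and compound 4 both lack a number, so no step can be read between them, and no measurement here bears on this result. The compounds shown leave open whether any group on the aromatic ring can improve on the unsubstituted compound 2 (100 mg/kg).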